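This account rests on a few compounds, and the source may have more. Where it says the series, first, only, none or still open, it means among the compounds named here.

Of the compounds shown here, three have so far been tested in a functional assay on HCT-116 cells (Homo sapiens) for cytotoxicity, read by sulforhodamine B assay, with a stated time of 24 h; on this read-out lower numbers stand for stronger inhibition and higher numbers for weaker inhibition. Compound 1 `CC(=O)Nc1ccn([C@H]2CC[C@H](O)[C@@H](C)O2)c(=O)n1` gives > 20000 nM, which is a limit of the assay rather than a number. Compound 3 `CC(C)CCC(=O)Nc1ccn([C@H]2CC[C@H](O)[C@@H](C)O2)c(=O)n1` gives > 20000 nM, again a limit and not a number. Among the measured compounds shown here, compound 2 `CCC(C)/C=C/C(=O)Nc1ccn([C@H]2CC[C@H](O[C@H]3O[C@H](C)[C@@H](N(C)C)[C@H](O)[C@H]3O)[C@@H](C)O2)c(=O)n1` is the only one to return a number, 890 nM, and so it stands alone among the measured values. For the measured compounds named here, the single traceable step, a step that the two limits leave unreadable from compound 1 to compound 3, cannot be read in size because the limit of > 20000 nM in this assay, at which 2 of the 3 values shown sit, hides both of its ends.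

The unmeasured compound 4 `CC(C)/C=C/C(=O)Nc1ccn([C@H]2CC[C@H](O[C@H]3O[C@H](C)[C@@H](N(C)C)[C@H](O)[C@H]3O)[C@@H](C)O2)c(=O)n1` differs from compound 2 by hydrogen in place of methyl on a saturated chain carbon, two bonds along the chain from a double-bonded chain carbon. The step from compound 1 to compound 3 also alters the chain attached to the carbonyl, but since its size is unreadable it offers no guide to how much trimming that chain matters. With no readable step bearing on this change, the expectation is for a step of a 1.6-fold higher number from compound 2 to compound 4 (0.20 log units; within the scatter), which is within the usual scatter, with a slight lean toward weaker inhibition.

Compound 4 is therefore estimated to give 1400 nM in this assay, in a range from 450 nM to 4500 nM.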

Compound 4, half-maximal inhibitory concentration: 780 nM
Estimate against measurement, compound 4: 1.8-fold (0.25 log units) above; the range from low to high includes it.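

In this assay, the chain on the carbonyl now has a step whose size can be read, a 1.1-fold lower number from compound 2 to compound 4 (0.06 log units; within the scatter), so compound 2 and compound 4 cannot be told apart on this read-out. Going from sec-butyl to isopropyl, which puts hydrogen in place of methyl on a saturated chain carbon, two bonds along the chain from a double-bonded chain carbon, therefore leaves no mark that this measurement can separate from ordinary repeat variation, and in this pair the methyl is not needed to keep a measurable number. The earlier step on the chain could not show this, since it cannot be read, and the reason lies in the assay's ceiling: the limit of > 20000 nM in this assay, at which 2 of the 4 values shown sit.

As far as these compounds go, what remains open is how far this tolerance reaches, since one pair differing by one methyl says nothing about a much longer chain, or about an amine or a carboxylic acid at the same carbon. It is also unknown whether the same change would behave alike on a chain without the double bond, and the data give no reason for the result in either direction.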